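A few compounds are considered here, and "the series" means these few. Any claim that something is new, unique, unknown or untested is made for them only; others in the source may bear on it.

Values measured so far in an ADME assay for pharmacokinetics; on this read-out higher numbers stand for a longer-lived compound and lower numbers for a shorter-lived compound:
- Compound 1 `NC(=O)c1ncn2c(=O)n(-c3ccccc3)nnc12`: 0.15 h
- Compound 2 `NC(=O)c1ncn2c(=O)n(-c3ccc(Cl)cc3)nnc12`: 0.137 h

On these two numbers, compound 2 cannot be told apart from compound 1. Among the measured compounds shown here, the single measured step, a 1.1-fold lower number from compound 1 to compound 2 (0.04 log units; within the scatter), lies within the usual scatter. The next compound to be measured, compound 3 `COc1ccc(-n2nnc3c(C(N)=O)ncn3c2=O)cc1`, differs from compound 2 in one place: methoxy in place of chloro on an aromatic carbon. Put simply, it carries methoxy in place of chloro on an aromatic carbon, para to a large group.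

For the measured compounds named here, only one measured step bears on this change, and it is indirect: it shows chloro in place of hydrogen on an aromatic carbon, and no compound with methoxy has a number yet. Going by the values given here, with a 1.1-fold lower number from compound 1 to compound 2 (0.04 log units; within the scatter) as the only guide, no step beyond the scatter is expected in this assay, and no direction can be favoured with any confidence. The expected change is a 1.1-fold higher number from compound 2 to compound 3 (0.04 log units; within the scatter), which is an estimate resting on very little evidence. For compound 3, the estimated half-life is 0.15 h, with an expected range of 0.08 h to 0.3 h.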

Compound 3, half-life: 0.142 h
The estimate for compound 3 lay 1.1-fold (0.02 log units) above the measured number; the measured number falls inside the stated range.
By their numbers in this assay, from the lowest: compounds 2, 3 and 1 (each within the scatter of the next).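

In this assay, the carbon para to a large group has now carried three different occupants, and the read-out separates none of them: methoxy in place of chloro gives a 1.0-fold higher number from compound 2 to compound 3 (0.02 log units; within the scatter), and methoxy in place of hydrogen gives a 1.1-fold lower number from compound 1 to compound 3 (0.02 log units; within the scatter). The earlier pair set only chloro against hydrogen, whereas methoxy enters with two heavy atoms and one hydrogen-bond acceptor, and hydrogen, chloro and methoxy still all stand within the scatter of one another. No further data are at hand to say what lies behind these closely grouped half-lives.

Going by these compounds, it remains open whether any other group at this carbon, such as an amine, a carboxylic acid or a longer chain like butoxy, would give a step beyond the scatter. On these data alone, since the three compounds share one core and differ only at this place, it is equally open whether a group placed elsewhere on the shared core would move the half-life.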